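The compounds below may be only part of what the source reports. "The series", "measured", "known", "first", "only" and "open" are said of these compounds alone.

Compound 2 `CN1CCC(NC(=O)c2ccncc2Nc2cc(-c3ccc4ccn(C)c4c3)c3nccnc3c2)CC1` is the more soluble of the two compounds measured in a physicochemical assay for solubility, read by spectrophotometry, measured as kinetic solubility, at pH 8, tested at 500 uM; a lower number here means a less soluble compound, a higher number a more soluble compound: compound 2 gives 246 ug/mL, while compound 1 `CN(Cc1cncnc1)S(=O)(=O)c1ccccc1Nc1cc(-c2ccc3ccn(C)c3c2)c2nccnc2c1` gives 3 ug/mL, a gap well beyond the scatter. Compound 3 `CN1CCC(N(C)C(=O)c2ccncc2Nc2cc(-c3ccc4ccn(C)c4c3)c3nccnc3c2)C1` keeps the core of compound 2 and differs from it in one place (methyl(1-methylpyrrolidin-3-yl)amino in place of (1-methylpiperidin-4-yl)amino on a carbonyl carbon). Going by the values given here, no measured pair shares this change, so the expectation for compound 3 rests on compound 2 and its value 246 ug/mL alone. The step of a 1.4-fold lower number from compound 2 to compound 3 (0.16 log units; within the scatter) is expected to stay within the scatter. Compound 3 is estimated at 170 ug/mL in this assay, with a likely range from 60 ug/mL to 400 ug/mL.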

Compound 3, solubility: 245 ug/mL
Compound 3: middle estimate off by 1.4-fold (0.16 log units), on the low side; the measured number falls inside the stated range.
By their numbers in this assay, from the lowest: compound 1; then compounds 3 and 2 (each within the scatter of the next).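

On a carbonyl carbon, methyl(1-methylpyrrolidin-3-yl)amino in place of (1-methylpiperidin-4-yl)amino gives a 1.0-fold lower number from compound 2 to compound 3 (0.00 log units; within the scatter) in this assay. At this position, the two groups are therefore not told apart by this read-out, even though the five-membered ring and 0 hydrogen-bond donors replace the six-membered ring and 1 hydrogen-bond donor. No supporting evidence bears on this result.

Ring size and donor count change together here, so their separate contributions remain open. Also open, on these data alone, is whether a ring-free group such as dimethylamino on the same carbonyl carbon would read like these two.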